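Aryl enone series: methoxy in place of methyl

The compounds below may be only part of what the source reports. "The series", "measured", "known", "first", "only" and "open" are said of these compounds alone.

Measured so far in a functional assay on HEK293 cells for antagonist activity at G-protein coupled receptor 52 (Homo sapiens), read by cAMP accumulation, with stated times of 15 min and 30 min; on this read-out higher numbers stand for weaker inhibition and lower numbers for stronger inhibition:
Compound 1 `Cc1ccccc1C(=O)/C=C/CCc1ccccc1` gives 2630 nM.
Compound 2 `Cc1cccc(C(=O)/C=C/CCc2ccccc2)c1` gives 2570 nM.
Compound 3 `Cc1ccc(C(=O)/C=C/CCc2ccccc2)cc1` gives 3020 nM.

Compound 3 carries the highest of the three numbers, yet its gaps to compound 1 and to compound 2 both lie within the scatter, so the three compounds read alike in this assay. Compound 4 `COc1ccc(C(=O)/C=C/CCc2ccccc2)cc1` differs from compound 3 by methoxy in place of methyl on an aromatic carbon. Within the data shown here, no measured pair in this set shows this exchange, so neither size nor direction of the step can be read from the data. Since compound 1, compound 2 and compound 3 sit together, the step is expected to be a 1.1-fold lower number from compound 3 to compound 4 (0.03 log units; within the scatter), not beyond the scatter. Compound 4 is therefore expected to give 2800 nM in this assay, within 1100 nM to 7000 nM.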

Compound 4, half-maximal inhibitory concentration: 3870 nM
Estimate against measurement, compound 4: 1.4-fold (0.14 log units) below; the measured number falls inside the stated range.
By their numbers in this assay, from the lowest: compounds 2, 1, 3 and 4 (each within the scatter of the next).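

In this assay the exchange of methyl for methoxy on an aromatic carbon, para to a large group, gives a 1.3-fold higher number from compound 3 to compound 4 (0.11 log units; within the scatter) and so stays within the scatter. This position therefore takes a second heavy atom and one hydrogen-bond acceptor without a step beyond the scatter, which the methyl compounds alone could not show. Nothing available here bears on the reason for this reading. On these data alone, whether methoxy reads the same at the ring positions held by methyl in compound 1 and compound 2 remains open. Also open, as far as these compounds go, is whether an amine, a carboxylic acid or a longer ethoxy chain at this position would move the number beyond the scatter.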